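The compounds below may be only part of what the source reports. "The series", "measured", "known", "first", "only" and "open" are said of these compounds alone.

Compound 1 `O=C(O)CCCCCCCn1nc(-c2ccccc2)c(-c2ccccc2)c1-c1ccccc1` is the only one of the three measured compounds that gives an actual number; the other two reach only limits. In a functional assay for inhibition, with Homo sapiens as the target (a higher number here means a weaker inhibitor, a lower number a stronger inhibitor), compound 1 gives 3400 nM. Compound 2 `O=C(O)CCCCCCn1cc(-c2ccccc2)c(-c2ccccc2)n1` reaches only a limit of this assay, > 92000 nM. Compound 3 `CC(C)(C)OC(=O)COCCCCCCn1nc(-c2ccccc2)c(-c2ccccc2)c1-c1ccccc1` also reaches only a limit, > 62000 nM. Going by the values given here, the one step between measured compounds that differ in a single place is large: an at least 18-fold higher number from compound 1 to compound 3 (1.26 log units; beyond the scatter), where (tert-butoxycarbonyl)methoxy replaces carboxymethyl on a saturated chain carbon, six bonds along the chain from an aromatic nitrogen.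

Compound 4 `c1ccc(-c2nn(CCCCCCCCc3nnn[nH]3)c(-c3ccccc3)c2-c2ccccc2)cc1` differs from compound 1 as follows: (1H-tetrazol-5-yl)methyl in place of carboxy on a saturated chain carbon, seven bonds along the chain from an aromatic nitrogen. Among the compounds with values here, the only measured step that bears on this is the replacement of the carboxymethyl in compound 3, which cost at least an at least 18-fold higher number from compound 1 to compound 3 (1.26 log units; beyond the scatter). The entering (1H-tetrazol-5-yl)methyl, unlike that ester, still carries a hydrogen-bond donor, so a smaller loss is expected: compound 4 is estimated at 6000 nM, between 1500 nM and 30000 nM, a step of a 1.8-fold higher number from compound 1 to compound 4 (0.25 log units; within the scatter).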

Compound 4, half-maximal inhibitory concentration: 1040 nM
Estimate against measurement, compound 4: 5.8-fold (0.76 log units) above, and the stated range ends above it.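

The carboxy group of compound 1 is not essential for activity in this assay: with (1H-tetrazol-5-yl)methyl in its place, the result is a 3.3-fold lower number from compound 1 to compound 4 (0.51 log units; beyond the scatter). The end of this chain can therefore improve inhibition as well as lose it, and 2-(1H-tetrazol-5-yl)ethyl in place of (tert-butoxycarbonyl)methoxy gives an at least 59-fold lower number from compound 3 to compound 4 (1.77 log units; beyond the scatter). That second step starts from a limit rather than from a real number: the limit of > 62000 nM in this assay, at which 1 of the 4 values shown sits.

The entering group differs from carboxy in both its ring and its extra carbon, so the compounds shown do not tell which of the two accounts for the gain. A 1H-tetrazol-5-yl group placed directly on the seven-carbon chain of compound 1 would separate them, and a primary amide at the same place would show how far other end groups can serve.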